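A few compounds are considered here, and "the series" means these few. Any claim that something is new, unique, unknown or untested is made for them only; others in the source may bear on it.

Three analogues built on a shared core have been measured so far. In a functional assay on MGC-803 cells (Homo sapiens) for inhibition, read by sulforhodamine B assay (on this read-out higher numbers stand for weaker inhibition and lower numbers for stronger inhibition), compound 1, `COc1cccc(NC2=CC(=O)c3c(nc4n3[C@H]3OC[C@@H](O)[C@H]3OC4)C2=O)c1`, gives 1790 nM. Compound 2, `Cc1ccc(NC2=CC(=O)c3nc4n(c3C2=O)[C@H]2OC[C@@H](O)[C@H]2OC4)cc1C`, gives 860 nM, and compound 3, `O=C1C=C(Nc2ccc(C(F)(F)F)cc2)C(=O)c2c1nc1n2[C@H]2OC[C@@H](O)[C@H]2OC1`, gives 2820 nM. Among these three numbers compound 1 stands second highest: its number and that of compound 3 lie within the scatter of each other, so nothing can be read into their order, while compound 2 gives a lower number than compound 1 and that gap does lie beyond the scatter. Among the compounds with values here, the only one-place step among the measured compounds is a 3.3-fold higher number from compound 2 to compound 3 (0.52 log units; beyond the scatter), a change of the whole aryl group on the amine nitrogen.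

Compound 4, `O=C1C(Nc2ccccc2)=CC(=O)c2c1nc1n2[C@H]2OC[C@@H](O)[C@H]2OC1`, differs from compound 1 by hydrogen in place of methoxy on an aromatic carbon. Within the data shown here, no measured step removes a methoxy group on its own; the step from compound 2 to compound 3 swaps one substituted aryl for another and so gives only a loose guide to how much a change on that ring can move this assay. On that basis, for compound 4 the expected result is a 1.0-fold higher number from compound 1 to compound 4 (0.00 log units; within the scatter), which is no change beyond the scatter. Compound 4 is therefore estimated at 1800 nM, with a likely range from 800 nM to 4000 nM.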

Compound 4, half-maximal inhibitory concentration: 1830 nM
The estimate for compound 4 lay 1.0-fold (0.01 log units) below the measured number; the range from low to high includes it.
By their numbers in this assay, from the lowest: compound 2; then compounds 1, 4 and 3 (each within the scatter of the next).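

Taking the methoxy group off the aromatic ring, at the carbon meta to a large group, gives a 1.0-fold higher number from compound 1 to compound 4 (0.01 log units; within the scatter) in this assay, so at this position the 3-methoxyphenyl and the plain phenyl cannot be told apart in this assay. Within the data shown here, this is the first measured step that changes a single substituent on that ring, whereas the earlier step, a 3.3-fold higher number from compound 2 to compound 3 (0.52 log units; beyond the scatter), replaced one substituted aryl group with another and could not show what any single group contributes. Nothing measured alongside these compounds bears on why the number stays put when the methoxy group leaves.

On these data alone, this single pair speaks only for methoxy and hydrogen at this one carbon, so it remains open whether a different group there, such as a hydroxyl, an amine, a carboxylic acid or a longer alkoxy chain, would shift the number beyond the scatter. It also leaves open whether a methoxy group on another carbon of the ring would behave in the same way, and the step between compound 2 and compound 3 cannot settle that question.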